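The source may report more compounds than this note shows. Statements on the series, on what has been measured and on what is new or still open speak of the compounds shown alone.

Three compounds have been measured in an assay for binding affinity to dual specificity mitogen-activated protein kinase kinase 4 (Homo sapiens), read by KINOMEscan, tested at 100 nM; on this read-out higher numbers stand for a weaker effect at the one concentration tested and lower numbers for a stronger effect:

compound 1, `CCCS(=O)(=O)Nc1ccc(F)c(C(=O)c2n[nH]c3ncc(-c4cccc(Cl)c4)cc23)c1F`: 40%
compound 2, `CCCS(=O)(=O)Nc1ccc(F)c(C(=O)c2n[nH]c3ncc(-c4ccccc4C)cc23)c1F`: 7%
compound 3, `CCCS(=O)(=O)Nc1ccc(F)c(C(=O)c2n[nH]c3ncc(-c4ccc(C)cc4)cc23)c1F`: 5.4%

Compound 2 stands second highest of the three numbers. Its nearest neighbour is compound 3, and the step of a number 1.6 percentage points lower from compound 2 to compound 3 (within the scatter) lies within the scatter, so the two cannot be told apart. Its furthest neighbour is compound 1, from which the step of a number 33 percentage points lower from compound 1 to compound 2 (beyond the scatter) is large, as is the parallel step a number 34.6 percentage points lower from compound 1 to compound 3 (beyond the scatter).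

Compound 4, `CCCS(=O)(=O)Nc1ccc(F)c(C(=O)c2n[nH]c3ncc(-c4cccc(O)c4)cc23)c1F`, has not yet been measured. It differs from compound 2 in one place: 3-hydroxyphenyl in place of 2-methylphenyl on an aromatic carbon. Among the compounds with values here, no measured step exchanges a methyl for a hydroxyl on this ring, so none bears on it directly. The two large steps from compound 1 show that the identity of the substituent on this ring can move the read-out in this assay by a great deal, while the step of a number 1.6 percentage points lower from compound 2 to compound 3 (within the scatter) shows that a change of position of the same group need not. Compound 4 carries a group that is neither a methyl nor a chloro, and the direction is therefore open, though a return toward the higher number of compound 1 is expected more than a further fall.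

The estimate for compound 4 is 20%, with a range from 5% to 50%, which is expected to amount to a step of a number 13 percentage points higher from compound 2 to compound 4 (beyond the scatter).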

Compound 4, a percentage reported as activity, at one concentration (the size of the read-out at that concentration, not a potency): 2.2%
For compound 4 the middle estimate is 17.8 percentage points above the measured one; the whole stated range lies above it.
By their numbers in this assay, from the lowest: compounds 4, 3 and 2 (each within the scatter of the next); then compound 1.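

In this assay, the 3-hydroxyphenyl group falls with the two methylphenyl groups and not with the 3-chlorophenyl group: the exchange of 2-methylphenyl for it gives a number 4.8 percentage points lower from compound 2 to compound 4 (within the scatter), and the exchange of 4-methylphenyl for it gives a number 3.2 percentage points lower from compound 3 to compound 4 (within the scatter), so a ring carrying a hydrogen-bond donor and acceptor reads like rings carrying neither. The new comparison also isolates a single substituent, since hydroxy in place of chloro gives a number 37.8 percentage points lower from compound 1 to compound 4 (beyond the scatter), which shows that the high number of the chloro compound depends on the chloro itself and not on substitution at that ring position as such; among these four compounds, the chloro compound alone stands apart. Nothing given here explains why the chloro compound differs from the other three.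

Still open, going by these compounds, is whether a 3-methylphenyl, a 3-aminophenyl or a carboxylic acid on this ring would read like compound 4 or like compound 1, which would show how far the low numbers extend. On these data alone, with only one concentration in this assay, the compounds within the low group cannot be ranked, and their potencies remain unknown.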